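Methoxy in Place of Methyl: Expected Growth Inhibition

The source may hold more compounds than are shown below. What is called first, only, known or untested is meant among the compounds shown, and "the series" means these compounds.

Compound 1 `COc1cc(C)nc2n/c(=N/C(=O)c3c(-c4ccc(Cl)cc4Cl)noc3C)sn12` and compound 3 `CSc1cc(C)nc(NC(=S)NC(=O)c2c(-c3ccc(Cl)cc3Cl)noc2C)n1` rest on different cores; the difference between the two cores is not broken down here. In a functional assay on the whole organism for inhibition, with Brassica napus as the target, with a stated time of 72 h, tested at 10 mg/L (a higher number here means more inhibition of growth at the concentration tested, a lower number less inhibition of growth), compound 1 gives 26.4%, compound 2 `COc1cc(SC)nc(NC(=S)NC(=O)c2c(-c3ccc(Cl)cc3Cl)noc2C)n1` gives 18.7%, and compound 3 gives 42.4%. Compound 3 becomes compound 2 through (methoxy in place of methyl on an aromatic carbon), and a number 23.7 percentage points lower from compound 3 to compound 2 (beyond the scatter). Compound 4 `COc1cc(OC)n2s/c(=N\C(=O)c3c(-c4ccc(Cl)cc4Cl)noc3C)nc2n1` arises from compound 1 through (methoxy in place of methyl on an aromatic carbon). This is the same kind of change, though the surroundings differ: in compound 1 the ring is part of a fused or bridged system of two rings, meta and para to a fused ring and meta to a methoxy group, whereas in compound 3 it is meta to a large group and meta to a methylsulfanyl group. The step of a number 14.4 percentage points lower from compound 1 to compound 4 (beyond the scatter) is expected to run in the same direction as the earlier one, resting on a number 23.7 percentage points lower from compound 3 to compound 2 (beyond the scatter). Compound 4 is therefore estimated at 12%, between 0% and 30%.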

Compound 4, percent growth inhibition at one concentration: 49.3%
Beside the measured number, compound 4's estimate is 37.3 percentage points below it; the whole stated range lies below it.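

In this assay, the swap of methyl for methoxy gives a number 22.9 percentage points higher from compound 1 to compound 4 (beyond the scatter), so on this evidence the change does not carry from one core to the other, not even in direction: the same change on two cores in this assay, a number 23.7 percentage points lower (beyond the scatter) from compound 3 to compound 2 and a number 22.9 percentage points higher (beyond the scatter) from compound 1 to compound 4, 46.6 percentage points apart, beyond the scatter of two such steps

This does not show why the two steps part ways. Each direction rests on a single pair, and the pairs differ both in core and in the neighbouring group on the ring, a methylsulfanyl group in one and a methoxy group in the other, so the core alone cannot be held responsible.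

The compounds shown leave open how an amine or an ethoxy group would behave at this place on the core of compound 1.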